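The source may report more compounds than this note shows. Statements on the series, on what has been measured and on what is new or still open speak of the compounds shown alone.

Measured so far in an ADME assay on BJ cells (Homo sapiens) for cytotoxicity, with a stated time of 72 h; a higher number here means that more compound is needed for the effect, a lower number that less compound is needed:
- compound 1 `COc1ccc(NC(=O)Nc2cc(C)nc3ccccc23)cc1Cl`: 23000 nM
- compound 2 `Cc1cc(NC(=O)Nc2ccc(OC(F)(F)F)cc2)c2ccccc2n1`: 25000 nM

Compound 2, at 25000 nM, stands level with compound 1, at 23000 nM: the two numbers lie within the scatter of each other, so no order can be drawn between them.

The next compound to be read is compound 3 `COc1ccc(NC(=O)Nc2cc(C)nc3ccccc23)cc1`. Its difference from compound 2 is methyl in place of trifluoromethyl on an oxygen on an aromatic ring. In words, this is methyl in place of trifluoromethyl on an oxygen on an aromatic ring, or trifluoromethoxy to methoxy.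

Among the measured compounds shown here, no measured pair differs in one place only, so this change has no direct precedent. For the measured compounds named here, the only guide is that compound 1, at 23000 nM, and compound 2, at 25000 nM, differ in structure yet fall within the scatter of each other. On that thin basis, no step beyond the scatter is expected in this assay, and no direction is favoured.

The estimated step of a 1.0-fold higher number from compound 2 to compound 3 (0.02 log units; within the scatter) stays within the scatter. For compound 3 the expected value is 26000 nM, with an estimated range of 12000 nM to 50000 nM.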

Compound 3, half-maximal effective concentration: > 25000 nM
Compound 3: only a limit was reported (the forecaster's own chance of this, stated with the estimate: 15%); the middle value lies beyond the limit too.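

In this assay compound 3 gives > 25000 nM, which is a limit and not a number: the limit of > 25000 nM in this assay, at which 1 of the 3 values shown sits.

Among the compounds shown here, this result supplies the first comparisons that differ in one place. Hydrogen in place of chloro on an aromatic carbon gives an at least 1.0-fold higher number from compound 1 to compound 3 (0.03 log units; that floor lies within the scatter), so the floor of this step shows no change beyond the scatter, while its upper end stays open. Methyl in place of trifluoromethyl on an oxygen on an aromatic ring gives a number no lower from compound 2 to compound 3 (the limit leaves the size open). The size of this step cannot be read, and only its direction is fixed: the number does not go lower with the methoxy group.

As far as these compounds go, the actual number for compound 3 remains open, and with it the true size of both changes. Also open, from the compounds shown here alone, is whether a longer chain such as ethyl on the oxygen, or an amine or a carboxylic acid in place of the chloro on that aromatic carbon, would give a number clearly apart from those seen so far in this assay.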